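The source may report more compounds than this note shows. Statements on the series, on what has been measured and on what is new or still open speak of the compounds shown alone.

Values so far in an ADME assay on microsomes from liver (Homo sapiens) for metabolic stability, with a stated time of 30 min (on this read-out higher numbers stand for a more stable compound and lower numbers for a less stable compound), are as follows:
- compound 1 (`COc1nc2c(cc1NCc1ccccc1F)c(=O)c(C(=O)O)cn2[C@H](CO)C(C)C`) gives 97%
- compound 2 (`COc1nc2c(cc1NCc1ccc(F)cc1F)c(=O)c(C(=O)O)cn2[C@H](CO)C(C)C`) gives 87%

Compound 2 stands at 87% and so within the scatter of compound 1 at 97% with no order to be read between the two.

The next structure is compound 3 (`COc1nc2c(cc1NCc1c(F)cc(F)cc1F)c(=O)c(C(=O)O)cn2[C@H](CO)C(C)C`). The change from compound 2 is fluoro in place of hydrogen on an aromatic carbon and reads as 2,4-difluorobenzyl to 2,4,6-trifluorobenzyl.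

Among the compounds with values here, the one measured step of the same kind is a number 10 percentage points lower from compound 1 to compound 2 (within the scatter) and it too is fluoro in place of hydrogen on an aromatic carbon. That step lies within the scatter. Within the data shown here, it is the only guide available, and it did not test the carbon that changes here. No step beyond the scatter is therefore expected in this assay from this change. The estimated move is a number 2 percentage points lower from compound 2 to compound 3 (within the scatter) and it is expected to stay within the scatter. For compound 3 an estimate of 85% is expected, with 70% to 97% as the likely range.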

Compound 3, percent of the compound remaining: 82%
Estimate against measurement, compound 3: 3 percentage points above; low and high end bracket the measured number.
By their numbers in this assay, from the lowest: compounds 3, 2 and 1 (each within the scatter of the next, the first and the last beyond it).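

Fluoro on this aromatic carbon, ortho to a large group and meta to two fluoro groups, is new to the series, and in this assay the single step there is a number 5 percentage points lower from compound 2 to compound 3 (within the scatter), so this carbon takes fluoro without a readable step on its own. Within the data shown here, the wider change from 2-fluorophenyl to 2,4,6-trifluorophenyl gives a number 15 percentage points lower from compound 1 to compound 3 (beyond the scatter), the first step beyond the scatter, although it is modest and neither of its single fluoro steps, the other being a number 10 percentage points lower from compound 1 to compound 2 (within the scatter), lies beyond the scatter by itself. No measurement accompanies these numbers that would account for the step.

Open, going by these compounds, is whether the modest step follows the number of fluoro groups or the carbons they occupy, and whether a chloro or methyl group on this same aromatic carbon would read like fluoro. Also open, on these data alone, is whether the same fluoro pattern reads alike with the carboxylic acid of the shared core replaced by an amide.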